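The source may hold more compounds than are shown below. What is called first, only, known or untested is meant among the compounds shown, and "the series" means these compounds.

Measured compounds:
- compound 1, `CCc1ccc(N(CC(C)C)S(=O)(=O)c2ccc3c(c2)C(=O)CC(c2c(C)noc2C)O3)cc1`: 4.42
- compound 2, `CCc1ccc(N(CC(C)C)S(=O)(=O)c2ccc3cc(OCC4CCOCC4)c(CO)cc3c2)cc1`: 5.1
- compound 3, `CC(C)CN(c1cccc(F)c1)S(=O)(=O)c1ccc2c(c1)C(=O)CC(C1CCOCC1)O2`: 3.5

These three have been run in a physicochemical assay for lipophilicity, at pH 7.4; a lower number here means a more polar compound, a higher number a more lipophilic compound. Within this set compound 1 sits in the middle: compound 2 lies higher by a margin beyond the scatter, and compound 3 lies lower by a margin that is also beyond the scatter, so compound 1 is neither the most nor the least lipophilic of the three. Going by the values given here, no two of the measured compounds differ in a single place, so no step between them can be read directly.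

The next compound, compound 4, `CCc1ccc(N(CC(C)C)S(=O)(=O)c2ccc3c(c2)C(=O)CC(C2CCN(S(C)(=O)=O)CC2)O3)cc1`, is to be measured in this assay. It is derived from compound 1 by one change, (1-(methylsulfonyl)piperidin-4-yl in place of 3,5-dimethyl-1,2-oxazol-4-yl on a saturated ring carbon). The group that leaves and the group that enters are both without charge and both carry two hydrogen-bond acceptors, but the incoming group is larger and non-aromatic and brings a sulfonyl. On the numbers available a moderate downward step is expected, beyond the scatter but not large. The estimated step from compound 1 to compound 4 is a number 0.42 log units lower from compound 1 to compound 4 (beyond the scatter). Compound 4 is therefore expected to give about 4, within 3.5 to 4.5.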

Compound 4, distribution coefficient: 3.31
Beside the measured number, compound 4's estimate is 0.69 log units above it; the whole stated range lies above it.
By their numbers in this assay, from the lowest: compounds 4 and 3 (each within the scatter of the next); then compound 1; then compound 2.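

Working notes on the saturated ring carbon next to the ring oxygen: this is the first single-place step in the series, and it shows that the group at this carbon can shift this assay substantially, with 1-(methylsulfonyl)piperidin-4-yl in place of 3,5-dimethyl-1,2-oxazol-4-yl giving a number 1.11 log units lower from compound 1 to compound 4 (beyond the scatter) on an otherwise unchanged core. The two groups have the same counts of hydrogen-bond donors and acceptors and neither carries a net charge, so in this pair a large step occurs without any change in those counts or in charge. Nothing measured here accounts for the size of the step.

The methylsulfonyl and the six-membered non-aromatic ring enter together, so the compounds shown do not divide the step between them. Also open, going by these compounds, is how this assay would read on the core of compound 1 with a piperidin-4-yl group carrying a free amine, with a 1-acetylpiperidin-4-yl group, or with a carboxylic acid on the same saturated ring carbon.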